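The source may hold more compounds than are shown below. What is called first, only, known or untested is meant among the compounds shown, and "the series" means these compounds.

Working notes on the sulfonylpiperidine series.

Three compounds have numbers in a functional assay on DLD-1 cells (Homo sapiens) for antiproliferative activity, read by CellTiter-Glo, with a stated time of 72 h; on this read-out higher numbers stand for weaker inhibition and lower numbers for stronger inhibition. Compound 1 `CC1CCN(C2CCN(S(=O)(=O)c3cccc(N)c3)CC2)CC1` gives 3400 nM. Compound 2 `Cc1ccc(S(=O)(=O)N2CCC(N3CCC(C)CC3)CC2)cc1C` gives 24 nM. Compound 3 `CCCOc1ccc(S(=O)(=O)N2CCC(N3CCC(C)CC3)CC2)cc1` gives 452 nM, which places it between compound 1 and compound 2, second highest of the three numbers. Within the data shown here, the only single-point step recorded so far is a 140-fold lower number from compound 1 to compound 2 (2.15 log units; beyond the scatter), showing that the group on the sulfonyl sulfur moves the read-out strongly.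

Compound 4 `CCc1ccc(S(=O)(=O)N2CCC(N3CCC(C)CC3)CC2)cc1` is not yet measured. It differs from compound 3 by ethyl in place of propoxy on an aromatic carbon. Among the measured compounds shown here, no measured step replaces one alkyl or alkoxy group with another on that ring, so the expectation rests on the spread across compounds 1, 2 and 3 rather than on a matching step. Because compound 2 with a 3,4-dimethylphenyl gives 24 nM, a lower number than compound 3 is expected for a plain ethyl-bearing ring, though with wide uncertainty. The estimated step is a 3.0-fold lower number from compound 3 to compound 4 (0.48 log units; beyond the scatter). For compound 4 the expected value is 150 nM, with a range from 40 nM to 600 nM.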

Compound 4, half-maximal inhibitory concentration: > 5000 nM
Compound 4: only a limit was reported; the forecaster's own chance of this, stated with the estimate: 2%; middle value at least 33-fold (1.52 log units) away from the limit.
By their numbers in this assay, from the lowest: compound 2; then compound 3; then compound 1. At a limit, above all of these: compound 4.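

In this assay compound 4 carries only a limit, not a number: the limit of > 5000 nM in this assay, at which 1 of the 4 values shown sits. The step of an at least 11-fold higher number from compound 3 to compound 4 (1.04 log units; beyond the scatter), with ethyl in place of propoxy on an aromatic carbon para to a large group, is the only one that isolates this position, and it shows that the read-out is highly sensitive to the change there. A lone ethyl does not reproduce the 3,4-dimethylphenyl result, as an at least 200-fold higher number from compound 2 to compound 4 (2.31 log units; beyond the scatter) shows, while an at least 1.4-fold higher number from compound 1 to compound 4 (0.16 log units; that floor lies within the scatter) gives that pair no firm order.

The compounds shown do not separate the oxygen of propoxy from the length of its chain; a propyl or an ethoxy at this position would do so. Also open, from the compounds shown here alone, is how a methyl alone at this position compares with the 3,4-dimethylphenyl.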